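The source may report more compounds than this note shows. Statements on the series, on what has been measured and on what is new or still open speak of the compounds shown alone.

Measured compounds:
compound 1 `CC1CCN(c2nc(C(F)(F)F)ccc2CNC(=O)Nc2cnc3ccccc3c2)CC1` — 9.5 nM
compound 2 `CC1CCN(c2nc(C(F)(F)F)ccc2CNC(=O)Nc2cncc3ccccc23)CC1` — 1.8 nM

In an assay on isolated protein for antagonist activity at transient receptor potential cation channel subfamily V member 1 (Homo sapiens), read by FLIPR (on this read-out lower numbers stand for stronger inhibition and higher numbers for weaker inhibition), compound 2 gives the lowest of the two numbers; its nearest neighbour is compound 1, with a 5.3-fold lower number from compound 1 to compound 2 (0.72 log units; beyond the scatter) separating them. Compound 3 `CC1CCN(c2nc(C(F)(F)F)ccc2CNC(=O)Nc2nccc3cccnc23)CC1` is not yet measured. It differs from compound 2 by a group of 10 heavy atoms (8 carbon, 2 nitrogen; 2 six-membered aromatic rings with 1 hetero atom each) in place of a group of 10 heavy atoms (9 carbon, 1 nitrogen; one six-membered aromatic ring of carbon only, one six-membered aromatic ring with 1 hetero atom), on an amide-type nitrogen. Going by the values given here, the one step that touches the same place is the exchange from compound 1 to compound 2, which gave a 5.3-fold lower number from compound 1 to compound 2 (0.72 log units; beyond the scatter), so this position does move the read-out in this assay beyond the scatter. Among the compounds with values here, no measured pair shows what putting a second hetero atom into the bicyclic group does, so the direction is open. A modest shift is expected rather than none, and the estimate for compound 3 is 4 nM, within 1.2 nM to 14 nM, which amounts to an expected 2.2-fold higher number from compound 2 to compound 3 (0.35 log units; beyond the scatter).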

Compound 3, inhibition constant: "not active" (no number reported)
Compound 3 has no reported number here; there is nothing to compare the estimate with.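

Going by these compounds alone, compound 3 is reported as not active, without a number, in this assay and so no step from compound 2 to compound 3 can be read. The compounds shown leave open how far apart these two compounds lie and what in the entering bicyclic group decides the outcome. Nothing shown bears on the reason for this result.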